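This account rests on a few compounds, and the source may have more. Where it says the series, first, only, none or still open, it means among the compounds named here.

Among the measured compounds shown here, two ureas of the series have numbers so far. For the measured compounds named here, compound 1 `C[C@H](NC(=O)Nc1ccccc1Cl)c1ccccc1` and compound 2 `C[C@@H](NC(=O)Nc1c(Cl)cccc1Cl)c1ccccc1` differ in more than one place, so no single-point step between them is counted. In an ADME assay on the whole organism with Oryza sativa as the target, tested at 10 uM (a higher number here means a weaker effect of the compound at the concentration tested, a lower number a stronger effect), compound 1 gives 106%, and in this assay compound 2 gives 100%. Going by the values given here, compound 2 carries the lowest of the two numbers, but its only neighbour, compound 1, sits within the scatter of it, so no order between the two can be stated, and the series offers no measured step to lean on.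

The next compound, compound 3 `C[C@H](NC(=O)Nc1c(Cl)cccc1Cl)c1ccccc1`, is the counterpart of compound 2 with the stereocentre at the saturated chain carbon drawn S rather than R: the two compounds have the same atoms and bonds and differ only in configuration as drawn: 1 of 1 stereo elements differ; a stereocentre at a saturated chain carbon is drawn R in compound 2 and S in compound 3. Nothing else moves. Among the compounds with values here, with both measured numbers close to each other and no measured step of any kind, the expectation in this assay is a step from compound 2 to compound 3 of about a number 3 percentage points higher from compound 2 to compound 3 (within the scatter), in no particular direction and not beyond the scatter. Compound 3 is therefore estimated at 103%, with a range from 88% to 118%.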

Compound 3, a percentage reported as activity, at one concentration (the size of the read-out at that concentration, not a potency): 99%
Compound 3: middle estimate off by 4 percentage points, on the high side; low and high end bracket the measured number.
By their numbers in this assay, from the lowest: compounds 3, 2 and 1 (each within the scatter of the next).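

The pair gives the series its first readable steps in this assay, and the one at the saturated chain carbon isolates the stereocentre, with a number 1 percentage points lower from compound 2 to compound 3 (within the scatter). Within this pair, then, the configuration as drawn does not separate the two numbers, and the comparison is a clean one: the fact that compounds 2 and 3 differ only in the configuration as drawn The second step, chloro in place of hydrogen on an aromatic carbon, gives a number 7 percentage points lower from compound 1 to compound 3 (within the scatter), so this change does not separate its two numbers either, and the two steps together show that neither the drawn configuration nor the added chloro moves the read-out beyond the scatter in these compounds.

All three numbers lie within the scatter of each other, so the compounds shown do not tell which part of the structure, if any, can shift the read-out at this concentration. Open, on these data alone, is whether a different group on an aromatic carbon, such as a nitrile or a carboxylic acid, or a longer chain at the saturated chain carbon, would give a step beyond the scatter.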